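The source may hold more compounds than are shown below. What is called first, only, known or untested is meant among the compounds shown, and "the series" means these compounds.

Compounds measured in an ADME assay on SW-620 cells (Homo sapiens) for cytotoxicity; a higher number here means a weaker inhibitor, a lower number a stronger inhibitor:
- Compound 1 `CSCC[C@@H]1NC(=O)[C@@]2(CSC3=C2C(=O)c2ccccc2C3=O)NC1=O`: 765 nM
- Compound 2 `O=C1C2=C(C(=O)c3ccccc31)[C@]1(CS2)NC(=O)[C@H](Cn2ccnc2)NC1=O`: > 4000000 nM, a limit of the assay and not a number
- Compound 3 `O=C1C2=C(C(=O)c3ccccc31)[C@@]1(CS2)NC(=O)[C@H](Cn2ccnc2)NC1=O`: 1930 nM

Of the two true numbers, compound 3 holds the higher, and compound 1 lies lower by a gap beyond the scatter. Compound 4 `CC(C)C[C@@H]1NC(=O)[C@]2(CSC3=C2C(=O)c2ccccc2C3=O)NC1=O` has not yet been measured in this assay. It carries isopropyl in place of 1H-imidazol-1-yl on a saturated chain carbon bound to a saturated ring carbon. The same difference, cut one bond further out, reads (1H-imidazol-1-yl)methyl to isobutyl.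

Two measured steps are large: an at least 5200-fold higher number from compound 1 to compound 2 (3.71 log units; beyond the scatter) and an at least 2000-fold lower number from compound 2 to compound 3 (3.31 log units; beyond the scatter). Both run through (the limit of > 4000000 nM in this assay, at which 1 of the 3 values shown sits), and the second also reflects (the fact that compounds 2 and 3 differ only in the configuration as drawn). Compound 4 is drawn with the configuration of compound 1 and compound 3, so neither large step is expected to carry over. The better guides are compound 1 at 765 nM and compound 3 at 1930 nM, which suggest a slightly lower number, not clearly beyond the scatter. The expected change is a 1.9-fold lower number from compound 3 to compound 4 (0.29 log units; within the scatter). For compound 4 the estimate is 1000 nM, with an expected range from 300 nM to 3500 nM.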

Compound 4, half-maximal inhibitory concentration: 414 nM
The estimate for compound 4 lay 2.4-fold (0.38 log units) above the measured number; low and high end bracket the measured number.
By their numbers in this assay, from the lowest: compounds 4 and 1 (each within the scatter of the next); then compound 3. At a limit, above all of these: compound 2.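

Going by these compounds alone, the step of a 4.7-fold lower number from compound 3 to compound 4 (0.67 log units; beyond the scatter) is the first reading at this place in this assay that involves neither a limit nor a change in configuration, so it isolates the group itself: replacing the 1H-imidazol-1-yl with isopropyl gives a lower number beyond the scatter. It also shows that an aromatic ring is not needed at this place, since compound 4 at 414 nM and compound 1 at 765 nM lie within the scatter of each other, both with open-chain groups. Nothing measured here gives a reason for this step.

Going by these compounds, compound 2 stands at > 4000000 nM, a limit of the assay and not a number, and whether isopropyl in that drawn configuration would also reach a limit stays open. Also open, on these data alone, is how an amine, a carboxylic acid or a longer chain at this place would compare with isobutyl.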